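A few compounds are considered here, and "the series" means these few. Any claim that something is new, unique, unknown or untested is made for them only; others in the source may bear on it.

Series notes. The cores of compound 2 `ClCc1ccccc1Cn1cnc2c(Cl)ncnc21` and compound 3 `ClCc1cccc(Cn2cnc3c(Cl)ncnc32)c1` hold the same atoms joined differently; the difference between the two cores is not broken down here. In a functional assay on HT-29 cells (Homo sapiens) for cytotoxicity, read by sulforhodamine B assay, with a stated time of 48 h (a higher number here means a weaker inhibitor of growth, a lower number a stronger inhibitor of growth), compound 2 gives 3540 nM and compound 3 gives 3230 nM, and the gap between the two lies within the usual scatter, so they stand level.

Compound 1 `ClCc1ccccc1Cn1cnc2c(Cl)nc(Cl)nc21` differs from compound 2 by chloro in place of hydrogen on an aromatic carbon. In this assay compound 1 gives 420 nM, which is a step of an 8.4-fold lower number from compound 2 to compound 1 (0.93 log units; beyond the scatter).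

Compound 4 `ClCc1cccc(Cn2cnc3c(Cl)nc(Cl)nc32)c1` is not yet measured and differs from compound 3 by chloro in place of hydrogen on an aromatic carbon. For the measured compounds named here, this is the same change as the one from compound 2 to compound 1: what leaves, what enters and the words describing the place agree completely. The change appears in two places in the set, once measured and once pending.

For compound 4 in this assay the expected step is an 8.1-fold lower number from compound 3 to compound 4 (0.91 log units; beyond the scatter). Going by the values given here, this rests on the single measured example of the change, an 8.4-fold lower number from compound 2 to compound 1 (0.93 log units; beyond the scatter), together with compound 3 starting from 3230 nM, a level close to the start of that measured step. A lone precedent carries limited weight, so the range is kept wide. Compound 4 is expected to give 400 nM, with a likely span from 150 nM to 1200 nM.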

Compound 4, concentration for 50% growth inhibition: 2390 nM
Compound 4: middle estimate off by 6.0-fold (0.78 log units), on the low side, and the stated range ends below it.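

In this assay, chloro in place of hydrogen on an aromatic carbon of the core of compound 3 gives a 1.4-fold lower number from compound 3 to compound 4 (0.13 log units; within the scatter), so this pair stands level and the large step seen on the other core does not recur here. The change therefore does not carry from one core to the other with a constant size, and a step measured on one of these cores is a poor guide to the other: the same change on two cores in this assay, an 8.4-fold lower number (0.93 log units; beyond the scatter) from compound 2 to compound 1 and a 1.4-fold lower number (0.13 log units; within the scatter) from compound 3 to compound 4, 6.2-fold (0.79 log units) apart, beyond the scatter of two such steps These two pairs show only that the size of the step differs between these two cores in this one assay; they do not show which difference between the cores lies behind the gap, nor whether either step is the more typical one for the series.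

The compounds shown leave open whether another group on the same aromatic carbon, such as an amine or a methoxy group, would also give steps that differ between the two cores. They also leave open how either core would respond if the chloromethyl group gave way to a hydroxymethyl group or a longer chain.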